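The source may hold more compounds than are shown below. What is called first, only, known or untested is meant among the compounds shown, and "the series" means these compounds.

Measured so far:
- Compound 1, `CCCCc1nc(=O)c(S(=O)(=O)c2ccc(-c3ccc(F)nc3)cc2)c(O)n1-c1c(OC)cccc1OC`: 2%
- Compound 2, `CCCCc1nc(=O)c(S(=O)(=O)c2ccc(-n3ccccc3=O)cc2)c(O)n1-c1c(OC)cccc1OC`: 83%
- Compound 3, `CCCCc1[nH]c(=O)c(S(=O)(=O)c2ccc(-c3ccc(F)nc3)cc2)c(O)c1-c1c(OC)cccc1OC`: "not determined" (no result reported)

The read-out throughout is an ADME assay on microsomes from liver (Rattus norvegicus) for metabolic stability, using NADPH, with a stated time of 10 min; a lower number here means that less of the compound is left, a higher number that more of the compound is left. Compound 1 and compound 2 share one core and differ in a single place: a group of 7 heavy atoms (5 carbon, 1 nitrogen, 1 oxygen; one six-membered aromatic ring with 1 hetero atom) in place of a group of 7 heavy atoms (5 carbon, 1 nitrogen, 1 fluorine; one six-membered aromatic ring with 1 hetero atom), on an aromatic carbon. That change made a large step, a number 81 percentage points higher from compound 1 to compound 2 (beyond the scatter), so with the 6-fluoropyridin-3-yl group very little of compound 1 was left, while with the pyridinone-type group most of compound 2 remained.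

Compound 3 carries a second core, and how the two cores differ is not broken down here. Compound 4, `CCCCc1[nH]c(=O)c(S(=O)(=O)c2ccc(-n3ccccc3=O)cc2)c(O)c1-c1c(OC)cccc1OC`, stands to compound 3 as compound 2 stands to compound 1: a group of 7 heavy atoms (5 carbon, 1 nitrogen, 1 oxygen; one six-membered aromatic ring with 1 hetero atom) in place of a group of 7 heavy atoms (5 carbon, 1 nitrogen, 1 fluorine; one six-membered aromatic ring with 1 hetero atom), on an aromatic carbon. The place of the change is described in the same words for both pairs, so it is the same change on a different core. For compound 3 itself no number exists, so the step from compound 3 to compound 4 cannot be anchored at its starting point.

Going by these compounds, for compound 4 in this assay the expectation is therefore a value near the level of compound 2, because the same change gave a number 81 percentage points higher from compound 1 to compound 2 (beyond the scatter); the estimate for compound 4 is 72%, with a likely range from 35% to 97%, the width reflecting that the effect on the second core is unknown.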

Compound 4, percent of the compound remaining: 100%
For compound 4 the middle estimate is 28 percentage points below the measured one, and the stated range ends below it.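

In this assay, going by these compounds alone, compound 4 gives 100%, but no step from compound 3 to compound 4 can be read, as compound 3 has no number to compare with. The compounds shown leave open whether replacing the 6-fluoropyridin-3-yl group changes the amount of compound left on the core of compound 3 as strongly as it does on the core of compound 1. Nothing available here offers an explanation for the result of compound 4.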